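Chain-end carbonyl variation in the sulfonamide series

A few compounds are considered here, and "the series" means these few. Any claim that something is new, unique, unknown or untested is made for them only; others in the source may bear on it.

Compound 3 `COc1cccc(Sc2c(NS(=O)(=O)c3ccc(C(C)(C)C)cc3)noc2CCC=O)c1` gives the lowest number of the three measured, 380 nM in an assay on A7R5 cells for displacement of a labelled ligand from Endothelin-1 receptor (Rattus norvegicus); on this read-out higher numbers stand for weaker inhibition and lower numbers for stronger inhibition. Compound 1 `COc1cccc(Sc2c(NS(=O)(=O)c3ccc(C(C)(C)C)cc3)noc2CCCCC=O)c1` gives 1400 nM and compound 2 `COc1cccc(Sc2c(NS(=O)(=O)c3ccc(C(C)(C)C)cc3)noc2CCCC(=O)O)c1` gives 4300 nM. Compound 4 `COc1cccc(Sc2c(NS(=O)(=O)c3ccc(C(C)(C)C)cc3)noc2CCCC(C)=O)c1` carries the change (2-oxopropyl in place of formyl on a saturated chain carbon, two bonds along the chain from an aromatic carbon). Relevant steps: a 3.7-fold lower number from compound 1 to compound 3 (0.57 log units; beyond the scatter), an 11-fold lower number from compound 2 to compound 3 (1.05 log units; beyond the scatter), and a 3.1-fold higher number from compound 1 to compound 2 (0.49 log units; beyond the scatter); each shows that moving the carbonyl further from the ring raises the number. Compound 4 places its carbonyl between those of compound 3 and compound 1, so a modest rise in this assay is expected, a 2.6-fold higher number from compound 3 to compound 4 (0.42 log units; beyond the scatter). Compound 4 is estimated at 1000 nM, ranging from 300 nM to 3500 nM.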

Compound 4, half-maximal inhibitory concentration: 1300 nM
The estimate for compound 4 lay 1.3-fold (0.11 log units) below the measured number, and the stated range covers the measured number.
By their numbers in this assay, from the lowest: compound 3; then compounds 4 and 1 (each within the scatter of the next); then compound 2.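

In this assay acetyl in place of formylmethyl gives a 1.1-fold lower number from compound 1 to compound 4 (0.03 log units; within the scatter) and so shifting the carbonyl along the chain, with the end group otherwise of the same size, leaves no readable difference here. Methyl in place of hydroxy on the carbonyl carbon gives a 3.3-fold lower number from compound 2 to compound 4 (0.52 log units; beyond the scatter) and 2-oxopropyl in place of formyl gives a 3.4-fold higher number from compound 3 to compound 4 (0.53 log units; beyond the scatter) so the rise goes with the longer end group and not with carbonyl position alone. No supporting measurement bears on these steps. Open, going by these compounds, is how a primary amide or an alcohol at the chain end would read against the ketone of compound 4. For the compounds shown here, a chain shorter than the one in compound 3 also remains open.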